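Removing the amino group: expected effect on solubility

The source may hold more compounds than are shown below. What is called first, only, known or untested is meant among the compounds shown, and "the series" means these compounds.

Compound 1, `CNc1nc(NC2CCOCC2)c2sc(-c3ccc(C(F)(F)F)cc3)cc2n1`, gives in a physicochemical assay for solubility, in phosphate buffer, at pH 6.5 (on this read-out lower numbers stand for lower solubility and higher numbers for higher solubility), only a limit, < 5 ug/mL.
Compound 2, `CN(C)CCCNc1nc(N)nc2cc(-c3ccc(C(F)(F)F)cc3)sc12`, gives in this assay a value of 148 ug/mL.

Within the data shown here, compound 2 stands as the only actual number in this assay; the other measurement is a limit, (the limit of < 5 ug/mL in this assay, at which 1 of the 2 values shown sits), which says nothing more than that. Among the measured compounds shown here, no step between measured compounds that differ in a single place is available, so the change toward compound 3 has to be judged without a measured reference. Compound 3, `CN(C)CCCNc1ncnc2cc(-c3ccc(C(F)(F)F)cc3)sc12`, keeps the (3-(dimethylamino)propyl)amino group and the shared core of compound 2 and differs in one place only: hydrogen in place of amino on an aromatic carbon. The amino group leaves, while the chain with its dimethylamino end remains. The step from compound 2 to compound 3 is expected to be small, most likely a modest fall in solubility that may not exceed the usual scatter, a 1.5-fold lower number from compound 2 to compound 3 (0.17 log units; within the scatter). Compound 3 is therefore expected to give about 100 ug/mL in this assay, with a plausible range from 40 ug/mL to 250 ug/mL.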

Compound 3, solubility: 205 ug/mL
The estimate for compound 3 lay 2.1-fold (0.31 log units) below the measured number; the measured number falls inside the stated range.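

Hydrogen in place of amino on the aromatic carbon between two ring nitrogen atoms, with the (3-(dimethylamino)propyl)amino group and the shared core left as they are, gives in this assay a 1.4-fold higher number from compound 2 to compound 3 (0.14 log units; within the scatter). This is the first comparison among the compounds shown that isolates a single place, and on this read-out it does not separate compound 2 from compound 3, so at this position the exchange of amino for hydrogen leaves no difference that can be told from the usual spread of repeated measurements. Nothing measured here speaks to why this step came out as it did.

On these data alone, whether a methyl group, a methoxy group or a methylamino group on this same aromatic carbon would also stay within the scatter of compound 3 remains open. Equally open, as far as these compounds go, is whether the exchange of amino for hydrogen would read the same if the dimethylamino end of the chain gave way to a morpholine or a carboxylic acid, since both compounds of this single pair carry that same chain.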